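Pyridine-carboxamide tetrazoles: phenoxy to propyl

This account rests on a few compounds, and the source may have more. Where it says the series, first, only, none or still open, it means among the compounds named here.

Measured so far:
compound 1 `O=C(Nc1nn[nH]n1)c1cccc(Oc2ccccc2)n1` — 0%
compound 2 `Cc1cccnc1C(=O)Nc1nn[nH]n1` — 69%
compound 3 `Cc1ccc(C(=O)Nc2nn[nH]n2)nc1C` — 42%

Three amides on a shared core have been run through a functional assay on the whole organism for inhibition, with Rattus norvegicus as the target, at a dose of 10 mg/kg by the oral route; a higher number here means a stronger effect of the compound at the dose given, a lower number a weaker effect. Compound 1 gives 0% and stands lowest of the three numbers; the gap to compound 3, which gives 42%, lies beyond the scatter, and the gap to compound 2, which gives 69%, is the widest and also beyond the scatter. No two of these compounds differ in a single place, so no step between measured compounds can be read off; compounds 2 and 3 merely show that a methyl-bearing core on its own reaches a sizeable inhibition.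

Compound 4 `CCCc1cccc(C(=O)Nc2nn[nH]n2)n1` is not yet measured. It differs from compound 1 as follows: propyl in place of phenoxy on an aromatic carbon.

Given that compound 1 shows 0% while the phenoxy-free compounds 2 and 3 both show clear inhibition, the removal of the phenoxy is expected to lift the read-out, so the step of a number 40 percentage points higher from compound 1 to compound 4 (beyond the scatter) is expected to be an increase beyond the scatter, though its size rests on two compounds that carry different groups. Compound 4 is estimated at 40%, within 10% to 70%.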

Compound 4, a percentage reported as inhibition, in the whole organism at one dose (the size of the read-out at that dose, not a potency): 38%
Compound 4: middle estimate off by 2 percentage points, on the high side, within the range that was stated.
By their numbers in this assay, from the lowest: compound 1; then compounds 4 and 3 (each within the scatter of the next); then compound 2.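

Propyl in place of phenoxy on an aromatic carbon, next to the ring nitrogen, gives in this assay a change of a number 38 percentage points higher from compound 1 to compound 4 (beyond the scatter) and is the first reading in the series that isolates a single place. A substituent at this place therefore does not in itself abolish the read-out: the shared core still reaches 38% in compound 4 with a propyl chain there, so the absence of inhibition in compound 1 goes with the phenoxy group in particular, not with the core or with substitution at this place as such. The change removes an oxygen, an aromatic ring and a hydrogen-bond acceptor together and also reduces the size of the group, so these features cannot be separated, and no measurement at hand bears on the reason for the step.

For the compounds shown here, compounds 2 and 3 differ from compound 4 in more than one place, so no steps to them can be read. Open at this place is how a phenyl group joined directly to the ring, a benzyl group, a butyl chain or an amine would compare, any of which could show whether the oxygen, the ring or the length of the group tracks with the read-out.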